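The source may report more compounds than this note shows. Statements on the series, on what has been measured and on what is new or still open speak of the compounds shown alone.

Measured so far:
compound 1, `CC(/C=N/Nc1ccc([N+](=O)[O-])cc1)=N\NC(=O)c1ccccc1F`: > 100000 nM
compound 2, `CC(/C=N/Nc1ccc([N+](=O)[O-])cc1)=N\NC(=O)c1cccc(C)c1`: > 100000 nM

In an ADME assay on J774 cells (Mus musculus, strain BALB/c) for cytotoxicity, read by resazurin assay, with a stated time of 72 h (a lower number here means that less compound is tolerated, a higher number that more compound is tolerated), compound 1 gives only a limit, > 100000 nM. Compound 2 likewise gives only a limit in this assay, > 100000 nM. The step that the two limits leave unreadable from compound 1 to compound 2 can thus not be read in size or direction; both values sit at the limit of > 100000 nM in this assay, at which 2 of the 2 values shown sit, so compound 2 stands on a limit and not on a number.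

Compound 3 `CC(/C=N/Nc1ccc([N+](=O)[O-])cc1)=N\NC(=O)c1ccccc1I` differs from compound 2 by 2-iodophenyl in place of 3-methylphenyl on a carbonyl carbon. Among the compounds with values here, the only measured step, a step that the two limits leave unreadable from compound 1 to compound 2, bears on a change at the same carbonyl carbon but gives no readable size, so no step beyond the scatter is expected from it. Compound 3 is expected to give a limit again, estimated at 150000 nM with a range from 50000 nM to 400000 nM. The expected step that the limit leaves unreadable from compound 2 to compound 3 is thus none beyond the scatter.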

Compound 3, half-maximal cytotoxic concentration: 40000 nM
Compound 3: the middle estimate sits 3.8-fold (0.57 log units) above what was measured; the whole stated range lies above it.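

In this assay, within the data shown here, compound 3 is the first compound here with a readable number rather than a limit, which shows that the group on the carbonyl carbon can change how much compound the cells tolerate. The change to 2-iodophenyl gives an at least 2.5-fold lower number from compound 2 to compound 3 (0.39 log units; beyond the scatter), while iodo in place of fluoro on an aromatic carbon gives an at least 2.5-fold lower number from compound 1 to compound 3 (0.39 log units; beyond the scatter); both are minimum sizes because the two reference values are limits: the limit of > 100000 nM in this assay, at which 2 of the 3 values shown sit. The earlier step between the two limits still cannot be read.

Open, from the compounds shown here alone, is whether the lower number is specific to iodo or would also appear with 2-chlorophenyl or 2-bromophenyl on the same carbonyl carbon. Also open, going by these compounds, is how an amine or a carboxylic acid on that aromatic ring would read in this assay.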